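The source may report more compounds than this note shows. Statements on the series, on what has been measured and on what is new or still open speak of the compounds shown alone.

Working notes on the series

The two measured compounds share one core and carry a 5-bromothiophen-2-yl group on the carbonyl carbon. Compound 1 `Cc1ccc2cc(/C=C/C(=O)c3ccc(Br)s3)c(Cl)nc2c1` in a functional assay on HUVEC cells (Homo sapiens), read by BrdU incorporation, with a stated time of 72 h (a higher number here means a weaker inhibitor, a lower number a stronger inhibitor), gives 83.6 nM. Compound 2 `Cc1ccc2nc(Cl)c(/C=C/C(=O)c3ccc(Br)s3)cc2c1`, which bears the same groups on the same core in a different arrangement, gives in this assay 88.4 nM. Among the measured compounds shown here, on the numbers in hand, compound 2 and compound 1 sit within the scatter of each other, so neither can be set apart from the other, and no step between measured compounds can be drawn from them.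

Compound 3 `Cc1ccc2nc(Cl)c(/C=C/C(=O)c3cc(C)sc3C)cc2c1` has not yet been measured. It differs from compound 2 in one place: 2,5-dimethylthiophen-3-yl in place of 5-bromothiophen-2-yl on a carbonyl carbon. For the measured compounds named here, no measured pair changes the group on the carbonyl carbon, so the size of this step has no precedent here. The expected step from compound 2 to compound 3 in this assay is a 1.7-fold higher number from compound 2 to compound 3 (0.23 log units; within the scatter), a modest weakening that may still fall within the scatter. Compound 3 is estimated at 150 nM, with a range from 50 nM to 500 nM.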

Compound 3, half-maximal inhibitory concentration: 229 nM
The estimate for compound 3 lay 1.5-fold (0.18 log units) below the measured number; measured number inside the range.
By their numbers in this assay, from the lowest: compounds 1 and 2 (each within the scatter of the next); then compound 3.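

Among the compounds shown here, this is the first step at the carbonyl carbon, and in this assay it can be read: 2,5-dimethylthiophen-3-yl in place of 5-bromothiophen-2-yl gives a 2.6-fold higher number from compound 2 to compound 3 (0.41 log units; beyond the scatter). The number at this position therefore responds to the group it carries, which compound 1 and compound 2 could not show, since both bear 5-bromothiophen-2-yl. The change alters several things at once, exchanging the bromine for two methyl groups and moving the point of attachment on the thiophene, and nothing available on the series accounts for the weakening.

The compounds shown leave open which of these changes carries the step, a question that 5-methylthiophen-2-yl or 5-bromothiophen-3-yl on the same carbonyl carbon would separate. Also open, as far as these compounds go, are whether a group other than a thiophene, such as a phenyl ring or a ring bearing an amine, is accepted at this position, and whether a step of this size also holds on the arrangement of compound 1.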